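This account rests on a few compounds, and the source may have more. Where it says the series, first, only, none or still open, it means among the compounds named here.

Of the compounds shown here, three of a shared core have been measured in a functional assay on NALM-6 cells (Homo sapiens) for cytotoxicity, read by MTT assay, with a stated time of 48 h; on this read-out lower numbers stand for stronger inhibition and higher numbers for weaker inhibition. Compound 1 `Cc1cc2oc(N)c(/C=N/NCCO)c(=O)c2cc1C` gives 65300 nM in this assay. Compound 2 `Nc1oc2ccc(Cl)cc2c(=O)c1/C=N/NCCO` gives 28000 nM in this assay. Compound 3 `Nc1oc2ccccc2c(=O)c1/C=N/Nc1cc(Cl)ccc1Cl` gives 500000 nM in this assay. Among these three numbers compound 2 stands lowest, and so is the most potent of the measured set: its nearest neighbour is compound 1, whose number lies higher by a margin beyond the usual scatter, and its furthest is compound 3, whose number lies far higher still.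

Compound 4 `Nc1oc2ccccc2c(=O)c1/C=N/NCCO` has not yet been measured. It differs from compound 2 in one place: hydrogen in place of chloro on an aromatic carbon. No measured pair of these compounds differs in exactly this way, so there is no measured step to lean on. Compound 1, which also lacks the chloro group and carries two methyl groups instead, gives a higher number than compound 2, which hints, weakly, that stripping the ring back may not help. For compound 4 a modest loss of potency is expected, with the step of a 1.8-fold higher number from compound 2 to compound 4 (0.25 log units; within the scatter) estimated to lie only a little beyond the scatter. Compound 4 is therefore estimated to give about 50000 nM in this assay, within a range from 20000 nM to 150000 nM.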

Compound 4, half-maximal inhibitory concentration: 42100 nM
The estimate for compound 4 lay 1.2-fold (0.07 log units) above the measured number; the range from low to high includes it.
By their numbers in this assay, from the lowest: compounds 2, 4 and 1 (each within the scatter of the next, the first and the last beyond it); then compound 3.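

In this assay, within the data shown here, putting hydrogen in place of chloro on this aromatic carbon gives a 1.5-fold higher number from compound 2 to compound 4 (0.18 log units; within the scatter) and so provides the first direct reading of this position. Compound 2 and compound 4 cannot be told apart in this assay, so the chloro group, a single heavy atom, is not needed to keep a number of this size on this core and with this chain. No measurement is available to explain this result.

Among the compounds shown, chloro and hydrogen are the only two groups that can be compared directly at this carbon, so it remains open whether a methoxy group, a bromo group or an amine there would shift the number beyond the scatter. On these data alone, it is also open whether the same swap would stay as small with a longer chain or a substituted phenyl ring in place of the hydroxyethyl chain, since this single pair shows the change in only one setting.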